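A Fluorine Changes Place in Compound 3

The source may report more compounds than this note shows. Statements on the series, on what has been measured and on what is new or still open speak of the compounds shown alone.

In an ADME assay on a cell-free system (plasma, Homo sapiens) for protein binding (on this read-out higher numbers stand for a larger free fraction and lower numbers for a smaller free fraction), compound 1 `COc1ccc(F)cc1C1CCN(c2ccn3c(CC(F)(F)F)nnc3c2Cl)CC1` gives < 0.01, a limit and not a number. Compound 2 `COc1ccc(F)cc1C1CCN(c2ccn3c(CC4CC4)nnc3c2Cl)CC1` gives < 0.01, also a limit. Both stand at the limit of < 0.01 in this assay, at which 2 of the 2 values shown sit. Going by the values given here, the only measured step is a step that the two limits leave unreadable from compound 1 to compound 2, and it lies elsewhere in the structure. Compound 3 `COc1c(F)cccc1C1CCN(c2ccn3c(CC4CC4)nnc3c2Cl)CC1` has the same atoms joined differently, with 3-fluoro-2-methoxyphenyl in place of 5-fluoro-2-methoxyphenyl on a saturated ring carbon. Among the compounds with values here, no measured step therefore sizes this change, and none beyond the scatter is expected in this assay. The expected step is a step that the limit leaves unreadable from compound 2 to compound 3. Compound 3 is estimated at 0.006, with an expected range of 0.002 to 0.015.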

Compound 3, unbound fraction: < 0.01
Compound 3 was reported as a limit (the forecaster's own chance of this, stated with the estimate: 85%); the middle value is on the limit's open side.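

Compound 2 and compound 3 are both reported as limits and not as numbers, so no step between them can be read: the limit of < 0.01 in this assay, at which 3 of the 3 values shown sit.

Going by these compounds, the actual free fraction of compound 1, compound 2 and compound 3 remains open, as does any difference among them.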